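This account rests on a few compounds, and the source may have more. Where it says the series, first, only, none or still open, it means among the compounds named here.

The shared core of compound 1 `O=c1[nH]cc(S(=O)(=O)Nc2cccc(-c3cn(-c4cccc(F)c4)nn3)c2)c(=O)[nH]1` carries a sulfonamide-linked phenyl ring that bears a five-membered aromatic ring with three nitrogens, and on one nitrogen of that ring a fluorophenyl group. In a functional assay on OVCAR-3 cells (Homo sapiens) for antiproliferative activity, read by MTT assay, with a stated time of 24 h (on this read-out lower numbers stand for stronger inhibition and higher numbers for weaker inhibition), compound 1 gives > 20000 nM, which is a limit of the assay and not a number. Compound 2 `O=c1[nH]cc(S(=O)(=O)Nc2cccc(-c3cn(-c4ccc(F)cc4)nn3)c2)c(=O)[nH]1` differs from compound 1 by 4-fluorophenyl in place of 3-fluorophenyl on an aromatic nitrogen. In this assay compound 2 gives > 20000 nM, again a limit and not a number. The step that the two limits leave unreadable from compound 1 to compound 2 therefore cannot be read, since both values sit at the limit of > 20000 nM in this assay, at which 3 of the 3 values shown sit.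

Compound 3 `O=c1[nH]cc(S(=O)(=O)Nc2ccc(-c3cn(-c4cccc(F)c4)nn3)cc2)c(=O)[nH]1` has a different core; the difference between the two cores is not broken down here. In this assay compound 3 gives > 20000 nM, once more a limit and not a number. For the measured compounds named here, all three measured compounds sit at the limit of > 20000 nM in this assay, at which 3 of the 3 values shown sit, so no compound can be called stronger or weaker than another.

Compound 4 `O=c1[nH]cc(S(=O)(=O)Nc2ccc(-c3cn(-c4ccc(F)cc4)nn3)cc2)c(=O)[nH]1` has not been measured. It differs from compound 3 by 4-fluorophenyl in place of 3-fluorophenyl on an aromatic nitrogen, the same change as from compound 1 to compound 2, at the same place. In this assay the step from compound 3 to compound 4 is expected to be a step that the limit leaves unreadable from compound 3 to compound 4, because the earlier step that the two limits leave unreadable from compound 1 to compound 2 stayed at the limit of > 20000 nM in this assay, at which 3 of the 3 values shown sit. For compound 4 the expected result is 30000 nM, most likely reported only as a limit, with a range from 15000 nM to 100000 nM.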

Compound 4, half-maximal inhibitory concentration: > 20000 nM
Compound 4 gave a limit, no number; the forecaster's own chance of this, stated with the estimate: 85%; the middle value does not contradict the limit.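

No size can be read for the step from compound 3 to compound 4, since each gives only a limit of the assay and not a number: the limit of > 20000 nM in this assay, at which 4 of the 4 values shown sit. The compounds shown leave open whether 4-fluorophenyl in place of 3-fluorophenyl makes any difference in this assay, and what change to the shared core would give a measurable value there.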